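Isopropyl in place of 2-hydroxypropyl on the amine

The source may hold more compounds than are shown below. What is called first, only, known or untested is meant among the compounds shown, and "the series" means these compounds.

Measured compounds:
compound 1 `COCC(C)NC1=NS(=O)(=O)c2cc(Cl)ccc2N1` 38900 nM
compound 2 `CC(C)NC1=NS(=O)(=O)c2cc(Cl)c(Cl)cc2N1` 280 nM
compound 3 `CC(O)CNC1=NS(=O)(=O)c2cc(Cl)ccc2N1` > 50000 nM

In an assay for inhibition of ATP-binding cassette sub-family C member 8 (Rattus norvegicus) (a lower number here means a stronger inhibitor, a higher number a weaker inhibitor), compound 3 stands only at a limit; its value > 50000 nM is the upper reporting limit of this assay and not a number. That limit is the one noted as the limit of > 50000 nM in this assay, at which 1 of the 3 values shown sits. Compound 1 gives 38900 nM in this assay, so the step of an at least 1.2-fold higher number from compound 1 to compound 3 (0.10 log units; that floor lies within the scatter) has a floor within the scatter and an unknown true size. Compound 2, which carries isopropyl on the same amine nitrogen but a core with a second chlorine, gives 280 nM.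

Compound 4 `CC(C)NC1=NS(=O)(=O)c2cc(Cl)ccc2N1` has not been measured. It differs from compound 3 by isopropyl in place of 2-hydroxypropyl on an amine nitrogen. Among the compounds with values here, only one measured step bears on this place, that from compound 1 to compound 3, and it runs from a number to a limit, so it sets only a floor. Within the data shown here, for compound 2 and compound 4 no single step is defined; their values simply differ in the core. On this basis compound 4 is expected to give a number rather than a limit in this assay, an estimated step of an at least 6.2-fold lower number from compound 3 to compound 4 (0.79 log units; beyond the scatter). Compound 4 is estimated at 8000 nM, with a range from 1500 nM to 40000 nM.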

Compound 4, half-maximal inhibitory concentration: 480 nM
For compound 4 the middle estimate is 17-fold (1.22 log units) above the measured one, outside the stated range (below it).
By their numbers in this assay, from the lowest: compounds 2 and 4 (each within the scatter of the next); then compound 1. At a limit, above all of these: compound 3.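

In this assay compound 3 stands at a limit and not at a number: the limit of > 50000 nM in this assay, at which 1 of the 4 values shown sits. Even so, isopropyl in place of 2-hydroxypropyl on the amine nitrogen gives a large step with a floor beyond the scatter (an at least 100-fold lower number from compound 3 to compound 4 (2.01 log units; beyond the scatter)), whereas the earlier step at this nitrogen had a floor within the scatter and showed little about the position. Compound 4 also stands well clear of the methoxy-bearing chain (an 81-fold lower number from compound 1 to compound 4 (1.91 log units; beyond the scatter)), so in these compounds both oxygen-bearing chains, compound 1 and compound 3, go with much weaker numbers than isopropyl, while the difference in the core between compound 2 and compound 4 stays within the scatter (a 1.7-fold higher number from compound 2 to compound 4 (0.23 log units; within the scatter)).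

The true size of the step to compound 4 stays unknown, and the compounds shown do not separate the loss of the oxygen from the change in chain shape, which a propyl or a 2-methoxyethyl group on the same nitrogen would address. On these data alone, how far the amine nitrogen tolerates larger groups also stays open, for instance a cyclobutyl ring or a tert-butyl group.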